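This account rests on a few compounds, and the source may have more. Where it says the series, first, only, none or still open, it means among the compounds named here.

Of the compounds shown here, three share a common core and have been measured in an assay on isolated protein for inhibition of Dihydrofolate reductase (Mus musculus); on this read-out higher numbers stand for higher potency (the scale is a negative logarithm) and lower numbers for lower potency. Compound 1, with the structure `CC1(C)N=C(N)N=C(N)N1c1ccc(Cl)c(OCCCOc2ccc(S(=O)(=O)F)cc2)c1`, gives 7.51 in this assay. Compound 2, `CC(Oc1ccc(N2C(N)=NC(N)=NC2(C)C)cc1Cl)C(=O)Nc1ccc(S(=O)(=O)F)cc1`, gives 7.13, and compound 3, `CC1(C)N=C(N)N=C(N)N1c1ccc(CCCCc2cccc(Cl)c2S(=O)(=O)F)c(Cl)c1`, gives 8.2. Among these three numbers compound 1 stands second highest: compound 2 lies lower by a step that exceeds the usual scatter, and compound 3 lies higher by a larger step that also exceeds it. Since no pair of these compounds differs in a single place, no individual structural step can be read from them.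

Compound 4, with the structure `CC1(C)N=C(N)N=C(N)N1c1cccc(OCCCOc2ccc(S(=O)(=O)F)cc2)c1`, has not yet been measured. It differs from compound 1 in one place: hydrogen in place of chloro on an aromatic carbon. The chloro sits on an aromatic carbon of a six-membered aromatic ring of carbon only, ortho to a large group and para to a large group, and in compound 4 a hydrogen takes its place.

Within the data shown here, no measured pair shows what this change does here, so the expectation rests on the structures alone. Removing the chloro is expected to lower potency somewhat, by a number 0.51 log units lower from compound 1 to compound 4 (beyond the scatter), a step beyond the scatter but modest. Compound 4 is thus estimated at 7, within a range from 6.4 to 7.6.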

Compound 4, logarithm of the reciprocal of the active concentration, log(1/C): 7.96
Compound 4: middle estimate off by 0.96 log units, on the low side, and the stated range ends below it.
By their numbers in this assay, from the lowest: compound 2; then compound 1; then compounds 4 and 3 (each within the scatter of the next).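

Swapping the chloro on this aromatic carbon, ortho to a large group and para to a large group, for hydrogen gives a number 0.45 log units higher from compound 1 to compound 4 (beyond the scatter) in this assay. With the chain of compound 1 in place, potency at this read-out therefore does not depend on having the chloro here, and the ring keeps its potency with no heavy atom at all at this carbon. Of the two groups seen at this position, hydrogen gives the higher number, but nothing measured here explains why the step goes in this direction.

Among these compounds, this single pair cannot say whether a group other than chloro, such as fluoro, methyl or methoxy, would give a number closer to that of compound 1 or to that of compound 4, so the position is defined by only two groups so far. It also leaves open whether the same swap would raise the number in compound 2 or compound 3, each of which has a different chain and a chloro of its own.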